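Notes on permeability across the sulfonamide-amide series

The source may report more compounds than this note shows. Statements on the series, on what has been measured and on what is new or still open speak of the compounds shown alone.

Measured compounds:
compound 1, `CNC(=O)C1=Cc2ccccc2S(=O)(=O)N1C`, 5.9 10^-6 cm/s
compound 2, `CCNC(=O)C1=Cc2ccccc2S(=O)(=O)N1C`, 5.9 10^-6 cm/s
compound 3, `CN1C(C(=O)NC2CC2)=C(Cl)c2ccccc2S1(=O)=O`, 12 10^-6 cm/s

In a physicochemical assay for permeability, using PAMPA, at pH 5.0 (a higher number here means that the compound crosses the layer faster, a lower number that the compound crosses the layer more slowly), compound 2 gives 5.9 10^-6 cm/s, level with compound 1, the pair forming the lowest numbers of the three; compound 3 reads higher, beyond the scatter. Compound 4, `CN1C(C(=O)NC2CC2)=Cc2ccccc2S1(=O)=O`, awaits measurement. The change from compound 2 to compound 4 is cyclopropyl in place of ethyl on an amide-type nitrogen. Within the data shown here, the only one-place step measured, no change at the digits printed from compound 1 to compound 2 (within the scatter), touches the same amide-type nitrogen and shows nothing beyond the scatter. Compound 3 also carries cyclopropyl, but differs from compound 4 in a second place, so its value alone cannot be read as a step. The expected step of a 1.3-fold higher number from compound 2 to compound 4 (0.10 log units; within the scatter) is therefore small, leaning upward. Compound 4 is estimated at 7.5 10^-6 cm/s, range 4 10^-6 cm/s to 13 10^-6 cm/s.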

Compound 4, apparent permeability: 5.9 10^-6 cm/s
The estimate for compound 4 lay 1.3-fold (0.10 log units) above the measured number; the measured number falls inside the stated range.
By their numbers in this assay, from the lowest: compounds 1, 2 and 4 (each within the scatter of the next); then compound 3.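

In this assay the ring of cyclopropyl on the amide-type nitrogen makes no difference against ethyl (no change at the digits printed from compound 2 to compound 4 (within the scatter)) or against methyl (no change at the digits printed from compound 1 to compound 4 (within the scatter)) so the three groups read level at this nitrogen. Hydrogen in place of chloro on the double-bonded ring carbon gives a 2.0-fold lower number from compound 3 to compound 4 (0.31 log units; beyond the scatter) so the higher number of compound 3 goes with the chloro and not with the cyclopropyl that both compounds carry. No measurement at hand gives a cause for either result.

From the compounds shown here alone, whether a longer chain or an amine on the amide-type nitrogen would also read level remains open. So does whether bromo or fluoro on the double-bonded ring carbon would match chloro.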